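The source may report more compounds than this note shows. Statements on the series, on what has been measured and on what is new or still open speak of the compounds shown alone.

Measured so far in a functional assay on HT-1080 cells (Homo sapiens) for cytotoxicity, read by MTT assay, with a stated time of 72 h; on this read-out higher numbers stand for weaker inhibition and lower numbers for stronger inhibition:
- Compound 1 `COc1cccc(/C=C2\CCC/C(=C\c3ccc(O)cc3)C2=O)c1OC` gives > 20000 nM as a limit
- Compound 2 `COc1cccc(/C=C2\CCC/C(=C\c3ccc(O)c(Cl)c3)C2=O)c1OC` gives 14300 nM
- Compound 3 `COc1ccc(/C=C2\CCC/C(=C\c3ccccc3Cl)C2=O)cc1OC` gives 6800 nM

Compound 3 holds the lowest number of the set. Compound 2 stands higher at 14300 nM by a gap beyond the scatter. Compound 4 `COc1ccc(/C=C2\CCC/C(=C\c3ccccc3Br)C2=O)cc1OC` differs from compound 3 by bromo in place of chloro on an aromatic carbon in one place, bromo in place of chloro on an aromatic carbon. Within the data shown here, no measured step exchanges one halogen for another. The nearest guide is an at least 1.3-fold lower number from compound 1 to compound 2 (0.14 log units; that floor lies within the scatter) and it puts chloro in place of hydrogen, so it bears only loosely. The expected change is a 1.0-fold lower number from compound 3 to compound 4 (0.02 log units; within the scatter) and is estimated to stay within the scatter of this assay measurements. Compound 4 is estimated at 6500 nM with an expected range from 3000 nM to 14000 nM in this read-out.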

Compound 4, half-maximal inhibitory concentration: 8400 nM
Compound 4: middle estimate off by 1.3-fold (0.11 log units), on the low side; low and high end bracket the measured number.
By their numbers in this assay, from the lowest: compounds 3, 4 and 2 (each within the scatter of the next, the first and the last beyond it). At a limit, above all of these: compound 1.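

Going from 2-chlorophenyl to 2-bromophenyl in this assay gives a 1.2-fold higher number from compound 3 to compound 4 (0.09 log units; within the scatter) and so, at this place ortho to a large group, the two halogens cannot be told apart on this read-out. Among these compounds, the earlier compounds held no exchange of one halogen for another, so this is the first view of such a swap. Nothing at hand on the properties of these compounds bears on this step.
The compounds shown leave open whether an amine or a carboxylic acid at this same place would keep the number at this level. They also leave open whether plain hydrogen there would do so.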